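From 3,5-dichlorophenyl to 2,5-dimethylphenyl in compound 4

The source may hold more compounds than are shown below. What is called first, only, known or untested is meant among the compounds shown, and "the series" means these compounds.

Measured in a functional assay on HL-60 cells (Homo sapiens) for inhibition, read by MTT assay, with a stated time of 72 h; a higher number here means a weaker inhibitor, a lower number a stronger inhibitor:
Compound 1 `Cc1ccc(C)c(N2CCN(C(=O)c3oc(C)nc3-c3ccc(F)cc3)CC2)c1` gives 358 nM
Compound 2 `Cc1ccc(C)c(N2CCN(C(=O)c3oc(C)nc3-c3ccccc3)CC2)c1` gives 31.3 nM
Compound 3 `Cc1nc(-c2cccc(F)c2)c(C(=O)N2CCN(c3cc(Cl)cc(Cl)c3)CC2)o1` gives 41.7 nM

Compound 3 lies within the scatter of compound 2 and well apart from compound 1. Compound 4 `Cc1ccc(C)c(N2CCN(C(=O)c3oc(C)nc3-c3cccc(F)c3)CC2)c1` has 2,5-dimethylphenyl in place of 3,5-dichlorophenyl on an amine nitrogen in a ring. Among the compounds with values here, no measured step makes this exact swap. The nearest evidence is an 11-fold lower number from compound 1 to compound 2 (1.06 log units; beyond the scatter), a large step on removing a fluoro group from a compound bearing 2,5-dimethylphenyl. Compound 4 has both that group and a fluoro group, as does compound 1 at 358 nM, so a moderate rise is expected, with wide uncertainty. The expected change is a 2.2-fold higher number from compound 3 to compound 4 (0.33 log units; beyond the scatter). For compound 4 the estimate is 90 nM, with an expected range from 25 nM to 320 nM.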

Compound 4, half-maximal inhibitory concentration: 204 nM
The estimate for compound 4 lay 2.3-fold (0.36 log units) below the measured number, and the stated range covers the measured number.
By their numbers in this assay, from the lowest: compounds 2 and 3 (each within the scatter of the next); then compounds 4 and 1 (each within the scatter of the next).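

In this assay, 2,5-dimethylphenyl in place of 3,5-dichlorophenyl gives a 4.9-fold higher number from compound 3 to compound 4 (0.69 log units; beyond the scatter), so the group on the ring amine nitrogen matters when 3-fluorophenyl is present. Fluoro in place of hydrogen gives a 6.5-fold higher number from compound 2 to compound 4 (0.81 log units; beyond the scatter), while 3-fluorophenyl in place of 4-fluorophenyl gives a 1.8-fold lower number from compound 1 to compound 4 (0.24 log units; within the scatter), so with 2,5-dimethylphenyl both fluorophenyl compounds are weaker than the unsubstituted phenyl compound 2. No measurement here explains these differences. Still open, as far as these compounds go, is whether a methoxy group or an amine in place of the fluoro group would be tolerated on this phenyl ring.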